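The source may report more compounds than this note shows. Statements on the series, on what has been measured and on what is new or still open speak of the compounds shown alone.

Measured in an ADME assay on HepG2 2.2.15 cells (Homo sapiens) for cytotoxicity; a lower number here means that less compound is tolerated, a higher number that more compound is tolerated:
- compound 1 `CCC(=O)OCCc1c(-c2ccccc2Cl)c2cc(Cl)ccc2[nH]c1=O`: 95000 nM
- compound 2 `CC(C)C(=O)OCCc1c(-c2ccccc2Cl)c2cc(Cl)ccc2[nH]c1=O`: 62000 nM

Compound 2 gives 62000 nM and stands within the scatter of compound 1, so the two cannot be ranked. The next compound, compound 3 `CCCCC(=O)OCCc1c(-c2ccccc2Cl)c2cc(Cl)ccc2[nH]c1=O`, has not yet been measured. It differs from compound 2 as follows: butyl in place of isopropyl on a carbonyl carbon. In short, it has butyl in place of isopropyl on a carbonyl carbon.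

Among the compounds with values here, only one measured step bears on this change: a 1.5-fold lower number from compound 1 to compound 2 (0.19 log units; within the scatter). That step also alters the group on the carbonyl carbon, and it stays within the scatter. Within the data shown here, it is a single small step, however, and no measured compound carries butyl, so the support is thin. On this evidence, no change beyond the scatter is expected in this assay, and no direction can be favoured with confidence. The estimated step is a 1.1-fold higher number from compound 2 to compound 3 (0.05 log units; within the scatter), which would be too small to separate the two compounds. For compound 3 the estimated value is 70000 nM, with an expected range from 35000 nM to 130000 nM.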

Compound 3, half-maximal cytotoxic concentration: 200000 nM
Compound 3: the middle estimate sits 2.9-fold (0.46 log units) below what was measured; the measured number lies above the stated range.
By their numbers in this assay, from the lowest: compounds 2 and 1 (each within the scatter of the next); then compound 3.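

In this assay, the group on the carbonyl carbon proves able to shift the number beyond the scatter, which the earlier pair did not show: butyl in place of isopropyl gives a 3.2-fold higher number from compound 2 to compound 3 (0.51 log units; beyond the scatter), and the comparison with the shorter ester gives a 2.1-fold higher number from compound 1 to compound 3 (0.32 log units; beyond the scatter). Both steps are modest, but they point the same way, so compound 3, with butyl, stands apart from the two earlier compounds, which themselves cannot be ranked; at this position, more compound is tolerated with butyl than with either earlier group. Nothing measured here accounts for this shift.

The compounds shown cannot separate the extra carbon of butyl from the loss of the branch in isopropyl, since both differences arrive together in the one change. As far as these compounds go, whether a longer unbranched chain such as hexyl would raise the number further, and whether a branched four-carbon group such as tert-butyl or an amine on the chain would keep the gain, remains open.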